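Swapping the Phenyl of Compound 2 for a Diethylamino Chain

The source may hold more compounds than are shown below. What is called first, only, known or untested is meant among the compounds shown, and "the series" means these compounds.

In a functional assay on the whole organism for antagonist activity, with Mus musculus as the target (a lower number here means that less compound is needed, a higher number that more compound is needed for the effect), compound 2 (`CN(C(=O)CNC(=O)c1ccccc1)c1ccc(Cl)cc1C(=O)c1ccccc1Cl`) gives 2.9 mg/kg as the lowest of two numbers, and compound 1 (`CN(C(=O)CNC(=O)CN1CCCCC1)c1ccc(Cl)cc1C(=O)c1ccccc1Cl`) gives 7.5 mg/kg as the other. Compound 3 (`CCN(CC)CC(=O)NCC(=O)N(C)c1ccc(Cl)cc1C(=O)c1ccccc1Cl`), not yet measured, has (diethylamino)methyl in place of phenyl on a carbonyl carbon. Among the measured compounds shown here, one measured step bears on this: a 2.6-fold lower number from compound 1 to compound 2 (0.41 log units; beyond the scatter) with phenyl in place of (piperidin-1-yl)methyl, modest but beyond the scatter. Read in reverse, it points to a similar step towards a higher number in this assay here. The expected change is a 2.4-fold higher number from compound 2 to compound 3 (0.38 log units; beyond the scatter) by this estimate. For compound 3 the estimated value is 7 mg/kg with a range from 3 mg/kg to 16 mg/kg overall.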

Compound 3, dose for half-maximal effect: 2.2 mg/kg
Beside the measured number, compound 3's estimate is 3.2-fold (0.50 log units) above it; the whole stated range lies above it.
By their numbers in this assay, from the lowest: compounds 3 and 2 (each within the scatter of the next); then compound 1.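

In this assay, (diethylamino)methyl in place of phenyl on this carbonyl carbon gives a 1.3-fold lower number from compound 2 to compound 3 (0.12 log units; within the scatter), so at this position the compounds shown do not require a six-membered aromatic ring. The amine itself matters: diethylamino in place of piperidin-1-yl gives a 3.4-fold lower number from compound 1 to compound 3 (0.53 log units; beyond the scatter), so the step from compound 1 to compound 2 cannot be read as applying to every amine chain. Nothing available explains this difference between the two amines. On these data alone, whether dimethylamino or morpholin-4-yl on that saturated chain carbon would match diethylamino or piperidin-1-yl remains open.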